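The source may hold more compounds than are shown below. What is called first, only, known or untested is meant among the compounds shown, and "the series" means these compounds.

In an ADME assay on Raji cells (Homo sapiens) for cytotoxicity, read by CellTiter-Glo and resazurin assay, with a stated time of 72 h (on this read-out higher numbers stand for an effect only at larger amounts of compound and lower numbers for an effect already at smaller amounts), three compounds have been examined so far, and each of them has reached only the limit of the assay rather than a number. Compound 1 `CC(C)N(Cc1cccc(OCCCCCC(=O)O)c1)C(=O)c1ccccc1` gives > 26000 nM, a limit. Compound 2 `CC(=O)c1cccc(-c2ccc(C(=O)N(Cc3cccc(OCCCCCC(=O)O)c3)C(C)C)cc2)c1`, which carries 3-acetylphenyl in place of hydrogen on an aromatic carbon, gives > 26000 nM, again a limit. Compound 3 `CCOC(=O)CCCCCOc1cccc(CN(C(=O)c2ccccc2)C(C)C)c1`, with ethyl in place of hydrogen on an oxygen next to a carbonyl group, gives > 26000 nM, also a limit. Compound 3 thus stands together with the other two at the limit of > 26000 nM in this assay, at which 3 of the 3 values shown sit. The step that the two limits leave unreadable from compound 1 to compound 2 and the step that the two limits leave unreadable from compound 1 to compound 3 cannot be sized, because both ends of each sit at the limit. Compound 4 `CCOC(=O)CCCCCOc1cccc(CN(C(=O)c2ccc(-c3ccc4ccccc4c3)cc2)C(C)C)c1` is the next compound to be measured, and it differs from compound 3 in one place: naphthalen-2-yl in place of hydrogen on an aromatic carbon. Within the data shown here, no measured step reports a change of this kind, and the two known steps give no readable size, so nothing in the data points to a step beyond the scatter in this assay. The expected step of an at least 1.3-fold lower number from compound 3 to compound 4 (0.11 log units; that floor lies within the scatter) is accordingly estimated as small. Compound 4 is expected to give about 20000 nM, with a range from 8000 nM to 45000 nM.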

Compound 4, half-maximal effective concentration: > 26000 nM
Compound 4 ended at the assay's limit; the forecaster's own chance of this, stated with the estimate: 60%; at least 1.3-fold (0.11 log units) between middle value and limit.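

In this assay compound 4 gives > 26000 nM, which is a limit. Compound 3 also sits at a limit, so the step between the two cannot be read. The compounds shown leave open which change to the shared core, if any, would give a readable number: the limit of > 26000 nM in this assay, at which 4 of the 4 values shown sit.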